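The source may report more compounds than this note shows. Statements on the series, on what has been measured and on what is new or still open speak of the compounds shown alone.

Working notes on the series. Among the measured compounds shown here, in a functional assay with Homo sapiens as the target (on this read-out lower numbers stand for stronger inhibition and higher numbers for weaker inhibition), compound 1 (`CC(C)[C@H](NC(=O)COc1cccc2ccccc12)C(=O)N[C@@H](CC(=O)O)C(=O)COc1ccc(C#N)cc1`) gives 26700 nM and compound 2 (`CC(C)[C@H](NC(=O)COc1cccc2ccccc12)C(=O)N[C@@H](CC(=O)O)C(=O)COc1ccc(F)c(F)c1F`) gives 20600 nM as the only two numbers so far. On these numbers compound 2 stands level with compound 1, and no order can be read between them.

Compound 3 (`CC(C)[C@H](NC(=O)COc1cccc2ccccc12)C(=O)N[C@@H](CC(=O)O)C(=O)COc1c(F)c(F)c(F)c(F)c1F`) brings one change, 2,3,4,5,6-pentafluorophenyl in place of 2,3,4-trifluorophenyl on an oxygen on a saturated carbon with 2,3,4,5,6-pentafluorophenyl in place of 2,3,4-trifluorophenyl on an oxygen on a saturated carbon. For the measured compounds named here, one measured step bears on it: a 1.3-fold lower number from compound 1 to compound 2 (0.11 log units; within the scatter) for 2,3,4-trifluorophenyl in place of 4-cyanophenyl at that same place. Going by the values given here, that step stayed within the scatter, although no measured pair varies the fluorine count alone.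

No move beyond the scatter is therefore expected in this assay and no firm direction. The expected change is a 1.1-fold lower number from compound 2 to compound 3 (0.06 log units; within the scatter) and nothing more. Compound 3 is estimated at 18000 nM (expected range 7000 nM to 40000 nM).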

Compound 3, half-maximal inhibitory concentration: 8890 nM
For compound 3 the middle estimate is 2.0-fold (0.31 log units) above the measured one; the range from low to high includes it.
By their numbers in this assay, from the lowest: compound 3; then compounds 2 and 1 (each within the scatter of the next).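

At this place, on an oxygen on a saturated carbon, the aryl group can shift the number in this assay beyond the scatter: 2,3,4,5,6-pentafluorophenyl in place of 2,3,4-trifluorophenyl gives a 2.3-fold lower number from compound 2 to compound 3 (0.36 log units; beyond the scatter) and, in place of 4-cyanophenyl, gives a 3.0-fold lower number from compound 1 to compound 3 (0.48 log units; beyond the scatter) as well. A rising fluorine count does not describe the whole set, since compound 1 carries no fluorine and the change to 2,3,4-trifluorophenyl stays within the scatter at a 1.3-fold lower number from compound 1 to compound 2 (0.11 log units; within the scatter) in this assay. Nothing available explains the gain seen with 2,3,4,5,6-pentafluorophenyl. Going by these compounds, it remains open whether all five fluorines are needed or whether a plain phenyl, a chlorophenyl or a cyclohexyl group on that oxygen would give a similar number. Also open, on these data alone, is whether the step would hold on a different core.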